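The source may report more compounds than this note shows. Statements on the series, on what has been measured and on what is new or still open speak of the compounds shown alone.

Of the compounds shown here, three built on one shared core have been tested in an ADME assay on HEK293 cells (Homo sapiens) for cytotoxicity, read by CellTiter-Glo and resazurin assay, with a stated time of 72 h; a lower number here means that less compound is needed, a higher number that more compound is needed for the effect. Compound 1 `CC(C)N(Cc1cccc(OCCCCCC(=O)O)c1)C(=O)c1ccc(-c2ccoc2)cc1` gives > 26000 nM in this assay, which is a limit of the assay rather than a measured number. Compound 2 `COc1cccc(-c2ccc(C(=O)N(Cc3cccc(OCCCCCC(=O)O)c3)C(C)C)cc2)c1` likewise gives only a limit, > 20900 nM. Compound 3 `CC(C)N(Cc1cccc(OCCCCCC(=O)O)c1)C(=O)c1ccc(-c2c[nH]c3ccccc23)cc1` also gives only a limit, > 26000 nM. With every value a limit, compound 1 cannot be ranked against the others: it shares the limit of > 26000 nM in this assay, at which 2 of the 3 values shown sit, with compound 3, while compound 2 sits at the limit of > 20900 nM in this assay, at which 1 of the 3 values shown sits. The measured steps, a step that the two limits leave unreadable from compound 1 to compound 2, a step that the two limits leave unreadable from compound 1 to compound 3 and a step that the two limits leave unreadable from compound 2 to compound 3, therefore have no readable size in this assay.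

Compound 4 `CC(C)N(Cc1cccc(OCCCCCC(=O)O)c1)C(=O)c1ccc(-c2ccc(Cl)c(Cl)c2)cc1` differs from compound 1 in one place: 3,4-dichlorophenyl in place of furan-3-yl on an aromatic carbon. Among the compounds with values here, the steps that bear on this change, from compound 1 to compound 2 and from compound 1 to compound 3, are both unreadable, so no step in this assay can be expected in either direction beyond the scatter. Compound 4 is expected to give about 26000 nM, within a range from 10000 nM to 60000 nM, most probably again reported only as a limit. That expectation corresponds to an estimated step of a number no higher from compound 1 to compound 4 (the limit leaves the size open).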

Compound 4, half-maximal effective concentration: > 26000 nM
Compound 4: a limit, no number (the forecaster's own chance of this, stated with the estimate: 80%); the middle value lies on the limit itself.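

Within the data shown here, compound 4 gives only a limit in this assay, as do compound 1, compound 2 and compound 3, so no step between compound 4 and any of the other three can be read. The compounds shown leave open what concentration any of them needs for the effect, and whether changing this group shifts it at all.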